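tert-Butoxycarbonyl Capping of an Amine and Solubility

A few compounds are considered here, and "the series" means these few. Any claim that something is new, unique, unknown or untested is made for them only; others in the source may bear on it.

Three related amides have been measured in a physicochemical assay for solubility; on this read-out lower numbers stand for lower solubility and higher numbers for higher solubility. Compound 3 `NCc1ccccc1NC(=O)c1cnc2ccccc2c1` gives 5 ug/mL, and compound 1 `CC(C)(C)OC(=O)NCc1ccccc1NC(=O)c1cnc2ccccc2c1` gives 15 ug/mL. The two differ in one place: tert-butoxycarbonyl in place of hydrogen on an amine nitrogen. For the measured compounds named here, that step, a 3.0-fold higher number from compound 3 to compound 1 (0.48 log units; beyond the scatter), is the only measured example of this change so far. Compound 2 `NCc1ccccc1NC(=O)c1ccc2ccccc2n1` holds the same atoms as compound 3 joined differently; the difference between the two cores is not broken down here. In this assay compound 2 gives 25 ug/mL, the highest of the three numbers, though its gap to compound 1 lies within the scatter. Compound 4 `CC(C)(C)OC(=O)NCc1ccccc1NC(=O)c1ccc2ccccc2n1` is not yet measured; it arises from compound 2 by the same change: tert-butoxycarbonyl in place of hydrogen on an amine nitrogen. The place of the change is the same in both pairs, so a similar step is expected. For compound 4 the expected step is a 2.4-fold higher number from compound 2 to compound 4 (0.38 log units; beyond the scatter), because the same change on the other core gave a 3.0-fold higher number from compound 3 to compound 1 (0.48 log units; beyond the scatter). With a single prior example, the range is kept wide: compound 4 is estimated at 60 ug/mL, between 20 ug/mL and 150 ug/mL.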

Compound 4, solubility: < 5 ug/mL
Compound 4: a limit, no number; the forecaster's own chance of this, stated with the estimate: 5%; at least 12-fold (1.07 log units) between middle value and limit.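

In this assay, the same change went in opposite directions on the two cores: the first pair shows a 3.0-fold higher number from compound 3 to compound 1 (0.48 log units; beyond the scatter), whereas the second shows an at least 5.0-fold lower number from compound 2 to compound 4 (0.69 log units; beyond the scatter). Compound 4 gives < 5 ug/mL, which is a limit of the assay and not a number, so the step has a known direction but no exact size: the limit of < 5 ug/mL in this assay, at which 1 of the 4 values shown sits. These two pairs show that a step seen with tert-butoxycarbonyl on one core cannot be assumed to carry over to the other core, but they do not show why the steps differ or what would happen on any further core.

The compounds shown leave open whether an acetyl group or a methyl group in place of hydrogen on the same amine nitrogen would also give steps in opposite directions on the two cores. Each would replace the hydrogen with a group other than tert-butoxycarbonyl, testing whether this split is limited to that one group.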